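Swapping a benzyl for a hexyl on a hydantoin-type scaffold

The source may report more compounds than this note shows. Statements on the series, on what has been measured and on what is new or still open speak of the compounds shown alone.

Of the compounds shown here, three share one core and have been tested in a functional assay on A549 cells (Homo sapiens) for antiproliferative activity, read by trypan blue exclusion, with a stated time of 72 h, tested at 20 uM; on this read-out lower numbers stand for less inhibition and higher numbers for more inhibition at the one concentration tested (going by the name of the read-out). Compound 1, `O=C1NC(=O)N(Cc2ccccc2)/C1=C/c1ccccc1`, gives 2.9%. Compound 2, `O=C1NC(=O)N(Cc2ccccc2)/C1=C\c1ccccc1`, gives 42%. Compound 3, `O=C1NC(=O)N(Cc2ccccc2)/C1=C\c1ccc(O)cc1`, gives 32%. Of the three numbers, that of compound 2 is not exceeded; compound 3 lies within the usual scatter of it, while compound 1 sits far lower. For the measured compounds named here, the one large step seen is a number 39.1 percentage points higher from compound 1 to compound 2 (beyond the scatter), and it rests on (the fact that compounds 1 and 2 differ only in the configuration as drawn). The step of a number 10 percentage points lower from compound 2 to compound 3 (within the scatter) is small.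

Compound 4, `CCCCCCN1C(=O)NC(=O)/C1=C/c1ccccc1`, differs from compound 2 in one place: pentyl in place of phenyl on a saturated chain carbon bound to an amide-type nitrogen in a ring. Neither measured step touches this part of the molecule: one changes the geometry of the double bond, the other adds a hydroxy on the aromatic ring at the far end. Going by the values given here, no measured step therefore tells how much the chain on the ring nitrogen matters. The expectation rests on compound 2 alone, and the change is taken to be modest in either direction. The estimated step of a number 10 percentage points lower from compound 2 to compound 4 (within the scatter) is expected to stay within or near the scatter. Compound 4 is thus expected to give about 32% in this assay, with a plausible range from 8% to 56%.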

Compound 4, a percentage reported as inhibition, at one concentration (the size of the read-out at that concentration, not a potency): 0%
Beside the measured number, compound 4's estimate is 32 percentage points above it; measured number outside the range, below it.
By their numbers in this assay, from the lowest: compounds 4 and 1 (each within the scatter of the next); then compounds 3 and 2 (each within the scatter of the next).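

At the position on a saturated chain carbon bound to an amide-type nitrogen in a ring, replacing phenyl with pentyl (benzyl to hexyl, one bond further out) gives in this assay a number 42 percentage points lower from compound 2 to compound 4 (beyond the scatter). For the compounds shown here, the earlier steps touched only the geometry of the double bond and the aromatic ring at the far end, so this is the first sign that the group on the ring nitrogen can matter, with a step as clearly beyond the scatter as a number 39.1 percentage points higher from compound 1 to compound 2 (beyond the scatter). The swap takes away a six-membered aromatic ring while the carbon count of the group moves only from 6 to 5, but nothing measured here gives a reason for the drop.

As far as these compounds go, it remains open whether the aromatic ring itself or the shape of the hexyl chain decides the outcome, and a cyclohexylmethyl group or a short methyl group on the ring nitrogen would help to separate the two. From the compounds shown here alone, how a substituted benzyl, such as one carrying a methoxy group, or a chain ending in an amine would behave at this position also stays unknown.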